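Swapping 4-fluorophenyl for 3-chlorophenyl in compound 3

The compounds below may be only part of what the source reports. "The series", "measured", "known", "first", "only" and "open" are said of these compounds alone.

Three compounds have been measured in a functional assay on A549 cells (Homo sapiens) for inhibition, read by sulforhodamine B assay (on this read-out lower numbers stand for stronger inhibition of growth and higher numbers for weaker inhibition of growth), so far:
- compound 1 `Cc1ccc2[nH]c(-c3ccc(-c4ccc(-c5ccc(N(C)C)cc5)cc4)cc3)nc2c1` gives 3510 nM
- compound 2 `COc1ccc(-c2ccc(-c3ccc(-c4nc5cc(C)ccc5[nH]4)cc3)cc2)cc1OC` gives 2100 nM
- compound 3 `Fc1ccc(-c2ccc(-c3ccc(-c4nc5ccccc5[nH]4)cc3)cc2)cc1` gives 33200 nM

Compound 3 has the highest number of the three, and its gaps to compound 1 and compound 2 lie beyond the scatter. Compound 4 `Clc1cccc(-c2ccc(-c3ccc(-c4nc5ccccc5[nH]4)cc3)cc2)c1` differs from it in one place, with 3-chlorophenyl in place of 4-fluorophenyl on an aromatic carbon and nothing else changes. Going by the values given here, only one measured step is a comparable swap on an aromatic carbon: a 1.7-fold lower number from compound 1 to compound 2 (0.22 log units; within the scatter) and it involves other groups. This thin guide gives no reason to expect a real shift in this assay here. The expected change is a 1.1-fold lower number from compound 3 to compound 4 (0.04 log units; within the scatter) and so no step beyond the scatter is expected. The estimate for compound 4 is 30000 nM and is expected to fall from 12000 nM to 75000 nM when measured.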

Compound 4, concentration for 50% growth inhibition: 31100 nM
Estimate against measurement, compound 4: 1.0-fold (0.02 log units) below; the range from low to high includes it.
By their numbers in this assay, from the lowest: compounds 2 and 1 (each within the scatter of the next); then compounds 4 and 3 (each within the scatter of the next).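

In this assay, replacing 4-fluorophenyl with 3-chlorophenyl gives a 1.1-fold lower number from compound 3 to compound 4 (0.03 log units; within the scatter), so this exchange of one halogen-bearing phenyl group for another, which also moves the halogen, leaves the reading within the scatter. Compound 4 therefore does not separate these two groups at this place. No measurement available here accounts for this result. From the compounds shown here alone, it remains open whether an amine or a carboxylic acid on this ring would move the number beyond the scatter. Compounds 1 and 2 differ from compounds 3 and 4 in more than one place, so their gap cannot be assigned to any single group.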